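A few compounds are considered here, and "the series" means these few. Any claim that something is new, unique, unknown or untested is made for them only; others in the source may bear on it.

Compound 1 `N=c1c2c(-c3ccccc3)c(-c3ccccc3)n(Cc3ccccc3)c2ncn1CCNc1ccncc1` and compound 2 `COc1ccc(-c2c(-c3ccc(OC)cc3)n(Cc3ccccc3)c3ncn(CCCO)c(=N)c23)cc1` share a core and were both examined in an ADME assay for permeability, using PAMPA, with a stated time of 30 min, at pH 7.4; a higher number here means that the compound crosses the layer faster, a lower number that the compound crosses the layer more slowly. In this assay compound 1 gives 445 10^-6 cm/s. For compound 2 the reading in this assay is > 1000 10^-6 cm/s, which is a limit of the method rather than a number. Compound 2 thus sits at the limit of > 1000 10^-6 cm/s in this assay, at which 1 of the 2 values shown sits, so its true value is not known beyond that boundary. Compound 3 `COc1ccc(-c2c(-c3ccc(OC)cc3)n(Cc3ccccc3)c3ncn([C@H]4CC[C@H](OC)CC4)c(=N)c23)cc1` has not yet been measured. It differs from compound 2 in one place: 4-methoxycyclohexyl in place of 3-hydroxypropyl on an aromatic nitrogen. Within the data shown here, no measured pair of compounds shows this change, so the size of the step can only be expected rather than read off. The step expected from compound 2 to compound 3 in this assay is a step that the limit leaves unreadable from compound 2 to compound 3, nothing beyond the usual scatter. Compound 3 is therefore estimated to give 1200 10^-6 cm/s, with a range from 600 10^-6 cm/s to 2500 10^-6 cm/s, and most probably the method will again report only a limit.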

Compound 3, apparent permeability: > 1000 10^-6 cm/s
Compound 3 was reported as a limit; the forecaster's own chance of this, stated with the estimate: 70%; the middle value is on the limit's open side.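

In this assay, among these compounds, compound 3 gives > 1000 10^-6 cm/s and this is a limit, as is the reading for compound 2, so no step from compound 2 to compound 3 can be read: the limit of > 1000 10^-6 cm/s in this assay, at which 2 of the 3 values shown sit. The compounds shown leave open how far past the limit each truly lies, and whether 4-methoxycyclohexyl in place of 3-hydroxypropyl changes the true value at all.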